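Isatin-free notes: stepping from compound 1 to compound 3

The compounds below may be only part of what the source reports. "The series", "measured", "known", "first", "only" and "open" are said of these compounds alone.

Cytotoxicity notes: from compound 1 to compound 3

- compound 1 `Cc1ccc(/N=C2\C(=O)Nc3ccc(S(=O)(=O)N4CCOCC4)cc32)cc1` with 309000 nM
- compound 2 `COc1ccc(-c2c(C#N)c(N)n(/N=C3\C(=O)Nc4ccc(S(=O)(=O)N5CCOCC5)cc43)c(=O)c2C#N)cc1` with 224000 nM

Both values come from an ADME assay on WI-38 cells (Homo sapiens) for cytotoxicity, read by sulforhodamine B assay, with a stated time of 24 h (on this read-out higher numbers stand for weaker inhibition and lower numbers for stronger inhibition), and they lie within the usual scatter of each other, so compound 1 cannot be ranked against compound 2 on these numbers. For the measured compounds named here, the next compound to be measured is compound 3 `CC(=O)N/N=C1\C(=O)Nc2ccc(S(=O)(=O)N3CCOCC3)cc21`, which keeps the core of compound 1 and carries acetamido in place of 4-methylphenyl on a double-bonded nitrogen as its only change. Going by the values given here, no measured pair differs in one place, so the data give no direct size for this change. The expectation rests on compound 1 at 309000 nM and compound 2 at 224000 nM as the only anchors. The expected change is a 1.2-fold lower number from compound 1 to compound 3 (0.07 log units; within the scatter) in this assay and so none beyond the scatter, with no direction favoured. For compound 3 the estimated value is 260000 nM with an expected range from 120000 nM to 500000 nM as its span.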

Compound 3, half-maximal inhibitory concentration: 325000 nM
For compound 3 the middle estimate is 1.3-fold (0.10 log units) below the measured one, and the stated range covers the measured number.
By their numbers in this assay, from the lowest: compounds 2, 1 and 3 (each within the scatter of the next).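

In this assay, for the compounds shown here, acetamido in place of 4-methylphenyl on a double-bonded nitrogen gives a 1.1-fold higher number from compound 1 to compound 3 (0.02 log units; within the scatter) as the first single-place step. At this position, a group with one six-membered aromatic ring of carbon only and no hydrogen-bond donors or acceptors can thus be exchanged for an open group with one donor and one acceptor, with no difference beyond the scatter. No available evidence bears on why the two groups read alike.

As far as these compounds go, whether a primary amine, a carboxylic acid or a longer alkyl chain on this nitrogen would give a step beyond the scatter remains open. Going by these compounds alone, the single step also leaves open whether changes elsewhere on the shared core would shift the number in this cell line.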